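Fluoro in Place of Trifluoromethyl on the Aryl Piperazine

The source may hold more compounds than are shown below. What is called first, only, known or untested is meant among the compounds shown, and "the series" means these compounds.

Measured compounds:
compound 1 `Cc1ccccc1COc1ccc(-c2cc(CN3CCN(Cc4ccc(C(F)(F)F)cc4)CC3)no2)cc1`: 6800 nM
compound 2 `FC(F)(F)c1ccc(CN2CCN(Cc3cc(-c4ccc(OCc5ccc(Cl)cc5)cc4)on3)CC2)cc1`: 3700 nM
compound 3 `N#Cc1cccc(COc2ccc(-c3cc(CN4CCN(c5ccc(C(F)(F)F)cc5)CC4)no3)cc2)c1`: 2700 nM

In a functional assay on Mahlavu cells (Homo sapiens) for antiproliferative activity, read by sulforhodamine B assay, with a stated time of 72 h (on this read-out higher numbers stand for weaker inhibition and lower numbers for stronger inhibition), compound 3 stands at the lowest of the three numbers. Its nearest neighbour is compound 2, whose value lies within the scatter of it, while compound 1 lies beyond the scatter above it. Compound 4 `N#Cc1cccc(COc2ccc(-c3cc(CN4CCN(c5ccc(F)cc5)CC4)no3)cc2)c1` differs from compound 3 by fluoro in place of trifluoromethyl on an aromatic carbon. Within the data shown here, the only measured step, a 1.8-fold lower number from compound 1 to compound 2 (0.26 log units; within the scatter), concerns the other end of the shared core and was itself within the scatter, so it gives no direct guide to the present change. Nothing measured here covers an exchange on the aryl piperazine. Compound 4 is therefore expected to give 3500 nM, with a range from 1400 nM to 9000 nM. The expected step is a 1.3-fold higher number from compound 3 to compound 4 (0.11 log units; within the scatter), not beyond the scatter.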

Compound 4, half-maximal inhibitory concentration: 2200 nM
Compound 4: middle estimate off by 1.6-fold (0.20 log units), on the high side; the measured number falls inside the stated range.
By their numbers in this assay, from the lowest: compounds 4, 3, 2 and 1 (each within the scatter of the next, the first and the last beyond it).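

In this assay, among these compounds, the first exchange at this aromatic carbon, from 4-(trifluoromethyl)phenyl to 4-fluorophenyl, gives a 1.2-fold lower number from compound 3 to compound 4 (0.09 log units; within the scatter). This position therefore accepts fluoro, with 1 heavy atom, in place of trifluoromethyl, with 4 heavy atoms, with no difference beyond the scatter in this assay. No available evidence bears on why this is so. The compounds shown leave open whether an amine, a carboxylic acid or a longer chain on this carbon would also stay within the scatter. They also leave open how a hydrogen there would compare.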